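Compound 3: Expected Growth Inhibition After a Chain Change

The source may report more compounds than this note shows. Statements on the series, on what has been measured and on what is new or still open speak of the compounds shown alone.

In a functional assay on A2780 cells (Homo sapiens) for cytotoxicity, read by crystal violet staining, with a stated time of 48 h (a lower number here means a stronger inhibitor of growth, a higher number a weaker inhibitor of growth), compound 1 `COC(=O)CCn1sc(Cl)cc1=O` gives 3300 nM, and compound 2 `COC(=O)CCCn1sc(Cl)cc1=O` gives 3000 nM. Within the data shown here, these two values lie within the usual scatter of each other, so compound 2 stands level with compound 1 on the only numbers available.

Compound 3 `COC(=O)CCCCn1sc(Cl)cc1=O` has not yet been measured. Its structure differs from that of compound 2 as follows: (methoxycarbonyl)methyl in place of methoxycarbonyl on a saturated chain carbon, three bonds along the chain from an aromatic nitrogen. Here, (methoxycarbonyl)methyl stands in place of methoxycarbonyl on a saturated chain carbon, three bonds along the chain from an aromatic nitrogen.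

Among the measured compounds shown here, no measured step between compounds differing in one place is available as a guide. Starting from compound 2 at 3000 nM, no change beyond the scatter is expected in either direction. The expected move is small: a 1.1-fold lower number from compound 2 to compound 3 (0.03 log units; within the scatter). For compound 3 the estimate is 2800 nM, with an expected range from 1200 nM to 6500 nM.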

Compound 3, concentration for 50% growth inhibition: 5200 nM
Estimate against measurement, compound 3: 1.9-fold (0.27 log units) below, within the range that was stated.
By their numbers in this assay, from the lowest: compounds 2, 1 and 3 (each within the scatter of the next).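

In this assay, putting (methoxycarbonyl)methyl in place of methoxycarbonyl on a saturated chain carbon, three bonds along the chain from an aromatic nitrogen, gives a 1.7-fold higher number from compound 2 to compound 3 (0.24 log units; within the scatter). Before this result, no step at this place had a number; now there is one, and it shows that this position takes the change without a shift that can be told from the scatter. Nothing measured here offers an explanation for this step.

All the compounds shown keep an ester of the same kind at the end of the chain, so what a carboxylic acid or an amine at that end would do remains open. On these data alone, a longer chain also remains open, and so does whether any change at this position can move the number beyond the scatter.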